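Replacing the selenium-bearing group of compound 3 with cyclopropyl

A few compounds are considered here, and "the series" means these few. Any claim that something is new, unique, unknown or untested is made for them only; others in the source may bear on it.

In a functional assay on KYSE-450 cells (Homo sapiens) for inhibition, read by MTT assay, with a stated time of 48 h (on this read-out lower numbers stand for stronger inhibition and higher numbers for weaker inhibition), compound 1 `COc1ccc(CN(C(C)=O)c2cc(OC)c(OC)c(OC)c2)cc1O` gives 160 nM and compound 2 `COc1ccc(CN(C(=O)CCl)c2cc(OC)c(OC)c(OC)c2)cc1O` gives 210 nM on the same read-out. Compound 3 `COc1ccc(CN(C(=O)C[Se]C#N)c2cc(OC)c(OC)c(OC)c2)cc1O` gives 280 nM there, which places it within the scatter of both other compounds. Compound 4 `COc1ccc(CN(C(=O)C2CC2)c2cc(OC)c(OC)c(OC)c2)cc1O` has not yet been measured. It differs from compound 3 by a group of 3 heavy atoms (3 carbon; one three-membered non-aromatic ring of carbon only) in place of a group of 4 heavy atoms (2 carbon, 1 nitrogen, 1 selenium; no ring), on a carbonyl carbon and keeps the shared core unchanged. The cyclopropyl group stands on a carbonyl carbon whose other neighbour is the amide-type nitrogen.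

Among the measured compounds shown here, three measured steps bear on this change. They are a 1.3-fold higher number from compound 1 to compound 2 (0.12 log units; within the scatter) for the chloro change, a 1.8-fold higher number from compound 1 to compound 3 (0.24 log units; within the scatter) for the selenium-bearing group against hydrogen, and a 1.3-fold higher number from compound 2 to compound 3 (0.12 log units; within the scatter) for that group against chloro. All three changes lie on a saturated chain carbon bound to a carbonyl carbon, and all three stay within the scatter. For the measured compounds named here, none of them places a three-membered ring on the carbonyl carbon, so the data offer no direct precedent for cyclopropyl. With only these small steps to go on, the expected step is a 1.4-fold lower number from compound 3 to compound 4 (0.15 log units; within the scatter) and it is not expected to exceed the scatter. For compound 4 the estimated value is 200 nM with an expected range from 80 nM to 500 nM in this assay.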

Compound 4, half-maximal inhibitory concentration: 80 nM
Compound 4: the middle estimate sits 2.5-fold (0.40 log units) above what was measured; low and high end bracket the measured number.
By their numbers in this assay, from the lowest: compounds 4, 1, 2 and 3 (each within the scatter of the next, the first and the last beyond it).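

Up to this point, every change on the saturated chain carbon bound to the carbonyl carbon had stayed within the scatter in this assay, so this part of the molecule had shown no clear sensitivity. Cyclopropyl on the carbonyl carbon is the first change here to go beyond the scatter, with a 3.5-fold lower number from compound 3 to compound 4 (0.54 log units; beyond the scatter) against the selenium-bearing group and a 2.6-fold lower number from compound 2 to compound 4 (0.42 log units; beyond the scatter) against chloromethyl, which shows that the group on this carbonyl carbon can shift the read-out measurably. The separation is only partial, however: cyclopropyl in place of methyl gives a 2.0-fold lower number from compound 1 to compound 4 (0.30 log units; within the scatter), so the two small groups cannot be told apart, and nothing available gives a reason for any of these steps.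

The compounds shown leave open whether the ring itself matters, since neither an open chain such as isopropyl nor a larger ring such as cyclobutyl stands on this carbonyl carbon. They also leave open how an amine or a carboxylic acid at the same place would read in this assay.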